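Replacing 2-oxocyclohexyl with 3-oxomorpholin-4-yl on compound 1

The source may hold more compounds than are shown below. What is called first, only, known or untested is meant among the compounds shown, and "the series" means these compounds.

For the measured compounds named here, in a physicochemical assay for lipophilicity, measured as octanol-water partition, at pH 7.4 (on this read-out higher numbers stand for higher lipophilicity and lower numbers for lower lipophilicity), compound 1 `CC(C)c1noc(N2CCC(Oc3cc(N4CCc5cc(C6CCCCC6=O)ccc54)ncn3)CC2)n1` gives 4.7, the highest of the three numbers measured so far. Compound 2 `CCc1cnc(N2CCC(C(C)COC(=O)N3CCc4cc(S(C)(=O)=O)cc(F)c43)CC2)nc1` gives 3.6, a gap beyond the usual scatter. Compound 3 `CC(C)c1noc(N2CCC(Oc3cc(N4CCc5cc(N6CCCS6(=O)=O)ccc54)ncn3)CC2)n1` gives 3.2, also beyond the scatter from compound 1.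

Compound 4 `CC(C)c1noc(N2CCC(Oc3cc(N4CCc5cc(N6CCOCC6=O)ccc54)ncn3)CC2)n1` has not yet been measured. It keeps the core of compound 1 but carries 3-oxomorpholin-4-yl in place of 2-oxocyclohexyl on an aromatic carbon. The ring that leaves is made of carbon only, while the ring that enters contains hetero atoms.

Going by the values given here, only one measured step bears on this change. Compound 3 also replaces 2-oxocyclohexyl with a non-aromatic ring containing hetero atoms, and that swap gives a number 1.50 log units lower from compound 1 to compound 3 (beyond the scatter). Compound 2 differs from compound 1 in more than one place, so it offers no direct guide. Among the compounds with values here, a single step is thin evidence, and the incoming ring in compound 3 is not the one in compound 4. A large drop in this assay, beyond the scatter and of similar size, is still expected, and the estimated change is a number 1.30 log units lower from compound 1 to compound 4 (beyond the scatter). For compound 4 the estimated value is 3.4, with an expected range from 2.9 to 3.9.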

Compound 4, distribution coefficient: 3.1
The estimate for compound 4 lay 0.30 log units above the measured number; the range from low to high includes it.
By their numbers in this assay, from the lowest: compounds 4 and 3 (each within the scatter of the next); then compound 2; then compound 1.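

In this assay, the swap to 3-oxomorpholin-4-yl gives a number 1.60 log units lower from compound 1 to compound 4 (beyond the scatter), so at this aromatic carbon a second ring with hetero atoms now follows the large drop that earlier rested on compound 3 alone. This drop arrives although the entering ring keeps the six-membered size, the heavy-atom count and the single double bond outside aromatic rings of 2-oxocyclohexyl, so neither ring size nor group size changes in this step; what changes is that carbon-only ring gives way to one with 2 hetero atoms. The two hetero-atom rings themselves differ in ring size and atom make-up, yet the step between them is a number 0.10 log units lower from compound 3 to compound 4 (within the scatter), and nothing measured here says why these swaps lower the number.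

Going by these compounds, whether an amine such as piperazin-1-yl, a carboxylic acid or an open-chain amide at this same aromatic carbon would land near compound 3 and compound 4 stays open. So does whether the same ring swap would give a drop of this size on a different core, such as that of compound 2.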